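Anilide para substituent: bromo to trifluoromethyl

The source may hold more compounds than are shown below. What is called first, only, known or untested is meant among the compounds shown, and "the series" means these compounds.

Compound 3 `O=C(Nc1ccc(Br)cc1)c1csc(Cc2c(Cl)cccc2Cl)n1` gives 400 nM in an assay on CHO cells, read by calcium flux (on this read-out lower numbers stand for stronger inhibition and higher numbers for weaker inhibition), the lowest of the two numbers in the series. Compound 1 `CCc1ccc(NC(=O)c2csc(Cc3c(Cl)cccc3Cl)n2)cc1` gives 810 nM in this assay, and the step is a 2.0-fold lower number from compound 1 to compound 3 (0.31 log units; beyond the scatter). Compound 2 `O=C(Nc1ccccc1)c1csc(Cc2c(Cl)cccc2Cl)n1` reaches only a limit, > 4000 nM in this assay, which is the limit of > 4000 nM in this assay, at which 1 of the 3 values shown sits. Compound 4 `O=C(Nc1ccc(C(F)(F)F)cc1)c1csc(Cc2c(Cl)cccc2Cl)n1` differs from compound 3 in one place: trifluoromethyl in place of bromo on an aromatic carbon. For the measured compounds named here, the steps that bear on this are an at least 10-fold lower number from compound 2 to compound 3 (1.00 log units; beyond the scatter) and a 2.0-fold lower number from compound 1 to compound 3 (0.31 log units; beyond the scatter), both pointing to a filled place giving lower numbers than hydrogen. Compound 4 keeps that place filled, so the expected step is a 1.3-fold higher number from compound 3 to compound 4 (0.10 log units; within the scatter), within the scatter. Compound 4 is thus estimated at 500 nM, with a range from 200 nM to 1300 nM.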

Compound 4, half-maximal inhibitory concentration: 140 nM
Compound 4: the middle estimate sits 3.6-fold (0.55 log units) above what was measured; the whole stated range lies above it.
By their numbers in this assay, from the lowest: compound 4; then compound 3; then compound 1. At a limit, above all of these: compound 2.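

In this assay, the choice of group at this position matters beyond simply filling it: a 2.9-fold lower number from compound 3 to compound 4 (0.46 log units; beyond the scatter), and a 5.8-fold lower number from compound 1 to compound 4 (0.76 log units; beyond the scatter). Trifluoromethyl gives the lowest number in the series and the widest gap from hydrogen, an at least 28-fold lower number from compound 2 to compound 4 (1.45 log units; beyond the scatter). Compound 2 stands at a limit, so that step is only a bound: the limit of > 4000 nM in this assay, at which 1 of the 4 values shown sits.

Going by these compounds, whether an amine, a carboxylic acid or a longer chain at this position would fall in line with compound 4, compound 3 and compound 1 stays open. On these data alone, whether the same order would hold with other groups on the rest of the shared core also stays open.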